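The source may report more compounds than this note shows. Statements on the series, on what has been measured and on what is new or still open speak of the compounds shown alone.

Compound 1 `COc1cc(C)cc(-c2c(-c3ccnc(-c4ccc(C(C)=O)cc4)c3)cnn2CC#N)c1` and compound 2 `Cc1cc(O)cc(-c2nn(CC#N)cc2-c2ccnc(-c3ccc(Oc4ccccc4)cc3)c2)c1` were both tested in a functional assay on SN12C cells (Homo sapiens) for cytotoxicity, read by sulforhodamine B assay, with a stated time of 48 h, tested at 1 uM; a lower number here means a stronger effect, a higher number a weaker effect of the compound at the concentration tested. In this assay compound 1 gives 28%, the higher of the two numbers, while compound 2 gives -57%, a gap beyond the usual scatter. Compound 3 `COc1cc(C)cc(-c2c(-c3ccnc(-c4ccc(N(C)C)cc4)c3)cnn2CC#N)c1` has not yet been measured. Compound 3 differs from compound 1 in one place: dimethylamino in place of acetyl on an aromatic carbon. Going by the values given here, with no measured step to guide it, the expected step of a number 8 percentage points lower from compound 1 to compound 3 (within the scatter) is small, and not beyond the scatter. The value of compound 3 is therefore estimated at 20%, within a range from -30% to 60%.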

Compound 3, a percentage reported as activity, at one concentration (the size of the read-out at that concentration, not a potency): 18%
Compound 3: the middle estimate sits 2 percentage points above what was measured, within the range that was stated.
By their numbers in this assay, from the lowest: compound 2; then compounds 3 and 1 (each within the scatter of the next).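

In this assay, dimethylamino in place of acetyl on this aromatic carbon, para to a large group, gives a number 10 percentage points lower from compound 1 to compound 3 (within the scatter). Going by these compounds alone, this is the first measured step at this position, and it shows that these two groups, each with the same count of heavy atoms, cannot be told apart in this read-out. Nothing measured here bears on the reason for this result. From the compounds shown here alone, whether a carboxylic acid or a longer chain at the same position would give a step beyond the scatter remains open.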